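Nitrile step carried from one core to another

This account rests on a few compounds, and the source may have more. Where it says the series, first, only, none or still open, it means among the compounds named here.

Values below come from a functional assay on HEK293 cells for agonist activity at Neuronal acetylcholine receptor; alpha4/beta2 (Homo sapiens), read by FLIPR; on this read-out lower numbers stand for an effect already at smaller amounts and higher numbers for an effect only at larger amounts of compound.

compound 1 `c1cncc(N2CC[C@H]3CN[C@H]3C2)c1`: 71 nM
compound 2 `N#Cc1cncc(N2CC[C@H]3CN[C@H]3C2)c1`: 1900 nM
compound 3 `c1cncc(N2C[C@@H]3CCNC[C@@H]32)c1`: 410 nM

Compound 1 and compound 3 are built from the same atoms joined differently; the difference between the two cores is not broken down here. Their values place compound 3 above compound 1 and below compound 2, both gaps beyond the scatter.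

From compound 1 to compound 2 the change is cyano in place of hydrogen on an aromatic carbon. This gives a 27-fold higher number from compound 1 to compound 2 (1.43 log units; beyond the scatter) in this assay.

Compound 4 `N#Cc1cncc(N2C[C@@H]3CCNC[C@@H]32)c1` carries the same change on the core of compound 3: cyano in place of hydrogen on an aromatic carbon. The place described is the same word for word, so this is the same change, now on the other core. Compound 4 is not yet measured in this assay.

For compound 4 a step of a 22-fold higher number from compound 3 to compound 4 (1.34 log units; beyond the scatter) is expected, because a 27-fold higher number from compound 1 to compound 2 (1.43 log units; beyond the scatter) is the single measured instance of this change and nothing in the shown compounds suggests the second core would respond differently. On this basis compound 4 is estimated at 9000 nM, with a likely range from 3000 nM to 30000 nM; a number this high may fall outside the assay window.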

Compound 4, half-maximal effective concentration: 2190 nM
For compound 4 the middle estimate is 4.1-fold (0.61 log units) above the measured one; the whole stated range lies above it.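

In this assay, cyano in place of hydrogen on an aromatic carbon moves the number the same way on the second core, with a 5.3-fold higher number from compound 3 to compound 4 (0.73 log units; beyond the scatter) on that core. The direction of the change therefore carries from one core to the other in this pair of cores, but its size does not, as the two steps differ by more than the scatter: the same change on two cores in this assay, a 27-fold higher number (1.43 log units; beyond the scatter) from compound 1 to compound 2 and a 5.3-fold higher number (0.73 log units; beyond the scatter) from compound 3 to compound 4, 5.0-fold (0.70 log units) apart, beyond the scatter of two such steps

Among these compounds, two cores give only one comparison, so these data do not show which feature of the cores goes with the smaller step, nor what size of step a further core would give.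

On these data alone, it remains open whether other groups in the same place, such as a chlorine atom, a methyl group or an amine, would also give different steps on the two cores. As far as these compounds go, it also remains open whether the cyano step would keep its direction on any core beyond these two.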